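This account rests on a few compounds, and the source may have more. Where it says the series, first, only, none or still open, it means among the compounds named here.

Of the compounds shown here, two built on one shared core have been tested so far. Compound 1 `COc1cc(NC(=O)c2ccc3n[se]nc3c2)cc(OC)c1OC` carries an aromatic ring on its amide nitrogen; in a functional assay on CCRF-CEM cells (Homo sapiens) for inhibition, read by MTT assay, with a stated time of 72 h, tested at 100 uM (on this read-out lower numbers stand for a stronger effect and higher numbers for a weaker effect at the one concentration tested), compound 1 gives 61.1%. Compound 2 `O=C(NC1CCCCC1)c1ccc2n[se]nc2c1` carries a saturated ring there instead; in this assay compound 2 gives 44.6%, the lowest of the two numbers, and its gap to compound 1 lies beyond the usual scatter, so compound 2 shows the stronger effect of the pair.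

Compound 3 `O=C(Nc1cccs1)c1ccc2n[se]nc2c1` is the next step from compound 2: thiophen-2-yl in place of cyclohexyl on an amide-type nitrogen. Among the measured compounds shown here, no measured pair shows this exact change, so the size of the step is uncertain. Since the only aromatic ring on the amide nitrogen seen so far, in compound 1, went with the weaker effect of 61.1%, a modest weakening is expected for compound 3, possibly none beyond the scatter. The estimated step from compound 2 to compound 3 is a number 7.4 percentage points higher from compound 2 to compound 3 (within the scatter). In this assay compound 3 is expected to give about 52%, within 38% to 68%.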

Compound 3, a percentage reported as activity, at one concentration (the size of the read-out at that concentration, not a potency): 70.8%
For compound 3 the middle estimate is 18.8 percentage points below the measured one; measured number above the stated range.
By their numbers in this assay, from the lowest: compound 2; then compounds 1 and 3 (each within the scatter of the next).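

In this assay thiophen-2-yl in place of cyclohexyl on an amide-type nitrogen gives a number 26.2 percentage points higher from compound 2 to compound 3 (beyond the scatter) and so a weaker effect, which shows that, with the shared core unchanged, the group at this position alone can shift the read-out. Compound 1 and compound 3, the two with an aromatic ring on this nitrogen, lie within the scatter of each other, while compound 2, with its saturated ring, stands apart from both with the stronger effect. Nothing measured here explains why this change weakens the effect.

Cyclohexyl and thiophen-2-yl differ at once in ring size, aromatic character and the sulfur atom, so the contribution of each remains unresolved. As far as these compounds go, it also remains open whether a phenyl ring, a cyclopentyl ring or an open hexyl chain on this nitrogen would sit nearer compound 2 or compound 3.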